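The source may hold more compounds than are shown below. What is called first, only, known or untested is meant among the compounds shown, and "the series" means these compounds.

Compound 1 `O=C(Nc1cccc(-n2cc(-c3ccncc3)c(-c3cc(O)cc(Cl)c3)n2)c1)Nc1ccc(Cl)c(C(F)(F)F)c1` and compound 2 `COc1cc(Cl)cc(-c2nn(-c3cccc(NC(=O)Nc4ccc(Cl)c(C(F)(F)F)c4)c3)cc2-c2ccncc2)c1` share one core, while compound 3 `O=C(Nc1cccc(-n2cc(-c3ccncc3)c(-c3cc(O)cc(Cl)c3)n2)c1)c1cc(C(F)(F)F)cc(C(F)(F)F)c1` and compound 4 `COc1cc(Cl)cc(-c2nn(-c3cccc(NC(=O)c4cc(C(F)(F)F)cc(C(F)(F)F)c4)c3)cc2-c2ccncc2)c1` share another; the difference between the two cores is not broken down here. In a functional assay on MDA-MB-231 cells (Homo sapiens) for inhibition, read by sulforhodamine B assay, with a stated time of 48 h, tested at 10 uM (on this read-out higher numbers stand for a weaker effect at the one concentration tested and lower numbers for a stronger effect), compound 1 gives -47.3%, compound 2 gives -30.8% and compound 3 gives -34.6%. Going by the values given here, the single change from compound 1 to compound 2 is methyl in place of hydrogen on an oxygen on an aromatic ring, and it made a step of a number 16.5 percentage points higher from compound 1 to compound 2 (beyond the scatter). The change from compound 3 to compound 4 is methyl in place of hydrogen on an oxygen on an aromatic ring, the same change at the same place, carried on the other core. Compound 4 has not yet been measured in this assay. Among the compounds with values here, the earlier pair is the only guide to what this change does, so a step of similar size is expected, a number 14.6 percentage points higher from compound 3 to compound 4 (beyond the scatter), with the caution that it rests on one pair and that the second core may not carry the change the same way. For compound 4 the expected number in this assay is therefore -20%, most likely between -36% and -4%.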

Compound 4, a percentage reported as activity, at one concentration (the size of the read-out at that concentration, not a potency): 56.7%
Beside the measured number, compound 4's estimate is 76.7 percentage points below it, outside the stated range (above it).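

In this assay, replacing hydroxy with methoxy on the aromatic ring weakens the effect on both cores, but by very different amounts, with the new step being a number 91.3 percentage points higher from compound 3 to compound 4 (beyond the scatter). The direction of the change carries over from one core to the other, but its size does not: the same change on two cores in this assay, a number 16.5 percentage points higher (beyond the scatter) from compound 1 to compound 2 and a number 91.3 percentage points higher (beyond the scatter) from compound 3 to compound 4, 74.8 percentage points apart, beyond the scatter of two such steps. Going by these compounds alone, with only two pairs, this shows that a step measured on one core can be a poor guide to its size on the other, but it does not show why the cores differ or whether other changes would behave the same way.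

The compounds shown carry only hydrogen or methyl on that oxygen, so they leave open what a longer chain such as ethyl, or a chain ending in an amine or a carboxylic acid, would do there on either core. They also leave open which part of the difference between the two cores matters, as compound 1 and compound 3 differ in more than one place.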